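Putting methylcarbamoyl back on the isopropyl group

The compounds below may be only part of what the source reports. "The series", "measured", "known", "first", "only" and "open" are said of these compounds alone.

Within the data shown here, in a physicochemical assay for lipophilicity, using the shake flask method, at pH 7.4 (on this read-out higher numbers stand for higher lipophilicity and lower numbers for lower lipophilicity), compound 2 (`COC(=O)N1CCN([C@H]2CC[C@H](Nc3ncnn4ccc(C(C)C)c34)CC2)CC1`) gives 3.3 and stands as the higher of the two numbers measured so far. Compound 1 (`COC(=O)N1CCN([C@H]2CC[C@H](Nc3ncnn4ccc([C@H](C)CC(=O)N(C)C)c34)CC2)CC1`) sits lower with 2.3 on this scale. Among the measured compounds shown here, compound 3 (`CNC(=O)C[C@@H](C)c1ccn2ncnc(N[C@H]3CC[C@H](N4CCN(C(=O)OC)CC4)CC3)c12`) has no measurement yet. It differs from compound 2 by methylcarbamoyl in place of hydrogen on a saturated chain carbon, two bonds along the chain from an aromatic carbon and the change reads as methylcarbamoyl in place of hydrogen on a saturated chain carbon, two bonds along the chain from an aromatic carbon. For the measured compounds named here, only one measured step bears on this, namely a number 1.00 log units higher from compound 1 to compound 2 (beyond the scatter) with hydrogen in place of dimethylcarbamoyl at that carbon. The new change runs the opposite way, with methylcarbamoyl entering. A fall of similar size is therefore expected in this assay and the estimated change is a number 1.20 log units lower from compound 2 to compound 3 (beyond the scatter) overall. Compound 3 is estimated at 2.1 (range 1.7 to 2.5).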

Compound 3, distribution coefficient: 2.2
Compound 3: the middle estimate sits 0.10 log units below what was measured; measured number inside the range.
By their numbers in this assay, from the lowest: compounds 3 and 1 (each within the scatter of the next); then compound 2.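

With a second amide, the fall on this saturated chain carbon is confirmed in this assay: the change from the isopropyl group to 1-((methylcarbamoyl)methyl)ethyl gives a number 1.10 log units lower from compound 2 to compound 3 (beyond the scatter), in the same direction as the earlier amide comparison implied. The two amides themselves cannot be told apart, since exchanging hydrogen for methyl on the amide-type nitrogen gives a number 0.10 log units lower from compound 1 to compound 3 (within the scatter), so the methyl there makes no difference that this read-out can resolve. Nothing available gives a measured reason for either step.

The compounds shown leave open whether this fall needs an amide at all, or whether a carboxylic acid, an amine or a longer chain on the same carbon would give a similar number. They also leave open whether a primary amide, with no methyl on its nitrogen, would stay level with compound 1 and compound 3.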